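An Ether Substituent on the Aromatic Ring of Compound 1

The source may hold more compounds than are shown below. What is called first, only, known or untested is meant among the compounds shown, and "the series" means these compounds.

Compound 1 `CC(C)=CCC/C(C)=C/CCC1=C[C@H](c2ccccc2)OC1=O` is the weaker of the two compounds measured in an assay on microsomes from liver for inhibition of 3-hydroxy-3-methylglutaryl-coenzyme A reductase (Sus scrofa), read by colorimetric assay (a lower number here means a stronger inhibitor, a higher number a weaker inhibitor), where compound 1 gives 16500 nM. Among the measured compounds shown here, its only neighbour, compound 2 `CC(C)=CCC/C(C)=C/CCC1=C[C@H](c2ccc([N+](=O)[O-])cc2)OC1=O`, gives 7430 nM, and the step of a 2.2-fold lower number from compound 1 to compound 2 (0.35 log units; beyond the scatter) is the sole measured change on the aromatic ring. Compound 3 `COCOc1ccccc1[C@H]1C=C(CC/C=C(\C)CCC=C(C)C)C(=O)O1` differs from compound 1 by methoxymethoxy in place of hydrogen on an aromatic carbon. That measured step involves a different group at a different place, so it bears only loosely on this change. The step of a 1.4-fold lower number from compound 1 to compound 3 (0.14 log units; within the scatter) is therefore expected to be small and to stay within the scatter. Compound 3 is accordingly estimated at 12000 nM, within 4000 nM to 40000 nM.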

Compound 3, half-maximal inhibitory concentration: 8900 nM
Compound 3: the middle estimate sits 1.3-fold (0.13 log units) above what was measured; measured number inside the range.
By their numbers in this assay, from the lowest: compounds 2, 3 and 1 (each within the scatter of the next, the first and the last beyond it).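

In this assay, the result is a 1.9-fold lower number from compound 1 to compound 3 (0.27 log units; within the scatter), so methoxymethoxy on an aromatic carbon ortho to a large group leaves the number within the scatter of compound 1. The earlier compounds shown here showed only what a nitro group does to the aromatic ring, and compound 3 adds that this chain of 4 heavy atoms can stand at this place without a step that can be told from the scatter. Nothing available explains this result. On these data alone, whether a hydroxyl, an amine or a carboxylic acid at this same place would keep the number within the scatter of compound 1 remains open.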